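This account rests on a few compounds, and the source may have more. Where it says the series, first, only, none or still open, it means among the compounds named here.

This account follows the step from compound 1 to compound 3. Compound 1 `COc1ccc(C(=O)/C=C/c2cccc(F)c2)c2c1C=CC(C)(C)O2` was tested in a functional assay on HCT-116 cells (Homo sapiens) for antiproliferative activity, read by MTT assay, with a stated time of 24 h (a higher number here means a weaker inhibitor, a lower number a stronger inhibitor), and reached only the limit of that measurement, giving > 10000 nM, which is a limit and not a number. Its close neighbour compound 2 `COc1ccc(C(=O)/C=C/c2cccc(C(F)(F)F)c2)c2c1C=CC(C)(C)O2` carries trifluoromethyl in place of fluoro on an aromatic carbon, and in this assay compound 2 gives 9710 nM. Going by the values given here, the only measured step, an at least 1.0-fold lower number from compound 1 to compound 2 (0.01 log units; that floor lies within the scatter), lies within the scatter, and one of the two values sits at the limit of > 10000 nM in this assay, at which 1 of the 2 values shown sits, so the measured data describe a flat, weak region rather than a trend.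

Compound 3 `COc1ccc(C(=O)/C=C/c2ccsc2)c2c1C=CC(C)(C)O2` differs from compound 1 in another place: thiophen-3-yl in place of 3-fluorophenyl on a double-bonded chain carbon bound to a double-bonded chain carbon. Among the compounds with values here, no measured step touches this position, and the one measured step, an at least 1.0-fold lower number from compound 1 to compound 2 (0.01 log units; that floor lies within the scatter), argues for no movement beyond the scatter at a nearby position. The author therefore expects no step beyond the scatter, a step that the limit leaves unreadable from compound 1 to compound 3, with the outcome for compound 3 likely again at or near the limit. For compound 3 in this assay the estimate is 15000 nM, with a range from 5000 nM to 50000 nM.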

Compound 3, half-maximal inhibitory concentration: > 10000 nM
Compound 3: a limit, no number; the forecaster's own chance of this, stated with the estimate: 60%; the middle value lies beyond the limit too.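

Compound 1 and compound 3 both stand at a limit of this assay rather than at a number, so no step between them can be read: the limit of > 10000 nM in this assay, at which 2 of the 3 values shown sit.

The compounds shown leave open how thiophen-3-yl and 3-fluorophenyl truly compare at this place, and whether any group there would give a value clear of the limit.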